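This account rests on a few compounds, and the source may have more. Where it says the series, first, only, none or still open, it means among the compounds named here.

In a functional assay on MCF7 cells (Homo sapiens) for inhibition, read by radiometric assay and XTT assay (a higher number here means a weaker inhibitor, a lower number a stronger inhibitor), compound 1 (`CCCCCC[C@@]1(C)SC(=O)C=C1OC`) gives 9.4 ug/mL, compound 2 (`CCCCCC[C@@]1(C)SC(=O)C=C1OCC(=O)OCC`) gives 39.6 ug/mL and compound 3 (`CCCCCCCC[C@@]1(C)SC(=O)C=C1OCC(=O)OCC`) gives 35.3 ug/mL. Compound 2 thus lies within the scatter of compound 3 and clearly apart from compound 1. Compound 4 (`CCCCCC[C@@]1(C)SC(=O)C=C1OCCCCCl`) differs from compound 2 by 3-chloropropyl in place of ethoxycarbonyl on a saturated chain carbon bound to an oxygen on an unsaturated carbon. The closest measured step is a 4.2-fold higher number from compound 1 to compound 2 (0.62 log units; beyond the scatter), which adds the ethoxycarbonyl group that compound 4 lacks. The other step, a 1.1-fold lower number from compound 2 to compound 3 (0.05 log units; within the scatter), changes a different chain and lies within the scatter. A partial reversal is therefore expected, an estimated 2.2-fold lower number from compound 2 to compound 4 (0.34 log units; beyond the scatter) in this assay. For compound 4 the expected value is 18 ug/mL, with an estimated range of 6 ug/mL to 45 ug/mL.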

Compound 4, half-maximal inhibitory concentration: 20.8 ug/mL
Beside the measured number, compound 4's estimate is 1.2-fold (0.06 log units) below it; the range from low to high includes it.
By their numbers in this assay, from the lowest: compound 1; then compounds 4, 3 and 2 (each within the scatter of the next).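

In this assay replacing ethoxycarbonyl with 3-chloropropyl at this position gives a 1.9-fold lower number from compound 2 to compound 4 (0.28 log units; within the scatter) and so stays within the scatter: a group with hydrogen-bond acceptors and a group with none cannot be told apart here. Adding 3-chloropropyl in place of hydrogen still gives a 2.2-fold higher number from compound 1 to compound 4 (0.34 log units; beyond the scatter) and lies beyond the scatter, so a weaker result at this position does not require ethoxycarbonyl.

No available evidence explains either step. Going by these compounds, whether an amine or a carboxylic acid at this position would also weaken inhibition remains open.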